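Nitro placement and chloro to dimethylamino swap

The source may hold more compounds than are shown below. What is called first, only, known or untested is meant among the compounds shown, and "the series" means these compounds.

Compound 2 `O=C1/C(=C/c2ccc(Cl)cc2)CCC/C1=C\c1ccc([N+](=O)[O-])cc1` and compound 3 `O=C1/C(=C/c2ccc(Cl)cc2)CCC/C1=C\c1ccccc1[N+](=O)[O-]` hold the same atoms joined differently; the difference between their two cores is not broken down here. In a functional assay on CCRF-CEM cells (Homo sapiens) for cytotoxicity, with a stated time of 72 h (on this read-out higher numbers stand for weaker inhibition and lower numbers for stronger inhibition), compound 3 gives 1750 nM, and compound 2 gives 8180 nM. Compound 1 `CN(C)c1ccc(/C=C2\CCC/C(=C\c3ccccc3[N+](=O)[O-])C2=O)cc1` carries dimethylamino in place of chloro on an aromatic carbon; in this assay compound 1 gives 168000 nM, which is a 96-fold higher number from compound 3 to compound 1 (1.98 log units; beyond the scatter). Compound 4 `CN(C)c1ccc(/C=C2\CCC/C(=C\c3ccc([N+](=O)[O-])cc3)C2=O)cc1` is not yet measured; relative to compound 2 it carries dimethylamino in place of chloro on an aromatic carbon, the same change, at the same place, as from compound 3 to compound 1. Within the data shown here, the step from compound 2 to compound 4 is expected to be about a 37-fold higher number from compound 2 to compound 4 (1.56 log units; beyond the scatter), resting on the one measured instance of this change, which was a 96-fold higher number from compound 3 to compound 1 (1.98 log units; beyond the scatter). Among the measured compounds shown here, only one instance is known, and the cores of compound 2 and compound 3 differ, so the expectation is loose. For compound 4 in this assay the estimate is 300000 nM, with a range from 50000 nM to 1500000 nM; a number this high may well be reported only as a limit.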

Compound 4, half-maximal inhibitory concentration: > 500000 nM
Compound 4 gave a limit, no number (the forecaster's own chance of this, stated with the estimate: 40%); middle value at least 1.6-fold (0.22 log units) from the limit.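

In this assay, compound 4 gives only a limit, > 500000 nM, and not a number. Dimethylamino in place of chloro moves the read-out the same way on both cores, with an at least 61-fold higher number from compound 2 to compound 4 (1.78 log units; beyond the scatter), so the direction of the change carries from one core to the other, but whether its size carries cannot be told: the same change on two cores in this assay, a 96-fold higher number (1.98 log units; beyond the scatter) from compound 3 to compound 1 and an at least 61-fold higher number (1.78 log units; beyond the scatter) from compound 2 to compound 4; the limit leaves it open whether they differ With dimethylamino held fixed, 4-nitrophenyl in place of 2-nitrophenyl gives an at least 2.9-fold higher number from compound 1 to compound 4 (0.47 log units; beyond the scatter), which runs the same way as the printed values of compound 3 and compound 2, though two cores are too few to make this a rule for the series.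

As far as these compounds go, only chloro and dimethylamino are compared at this place, so it remains open whether a methoxy group or a primary amine there would sit nearer the chloro compounds or the dimethylamino compounds. From the compounds shown here alone, the size of the dimethylamino step on the core of compound 2 also remains open beyond its lower bound.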